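The compounds below may be only part of what the source reports. "The series", "measured", "known", "first", "only" and "open" are said of these compounds alone.

Of the compounds shown here, three have been measured in a functional assay on cells for positive allosteric modulation of metabotropic glutamate receptor 2 (Homo sapiens), read by fluorescence and calcium flux, with a stated time of 30 min; on this read-out lower numbers stand for an effect already at smaller amounts and higher numbers for an effect only at larger amounts of compound. Compound 1 `Clc1ccc(-c2ccc(Cn3nnc4ccccc43)cn2)cc1` gives 70 nM, compound 2 `Fc1ccccc1Cn1nnc2c(Br)cccc21` gives 64 nM, and compound 3 `Brc1cc(Br)c2nnn(CC3CC3)c2c1` gives 50 nM. Compound 3 shows the smallest of the three numbers, yet its gaps to compound 2 and to compound 1 both lie within the usual scatter of repeated measurements, so the three cannot be told apart. Compound 4 `COc1cc(Br)c2nnn(CC3CC3)c2c1` has not yet been measured; it differs from compound 3 in one place: methoxy in place of bromo on an aromatic carbon. Among the measured compounds shown here, no comparable step between measured compounds exists, so a small step toward a higher number is expected, of the size a 1.8-fold higher number from compound 3 to compound 4 (0.26 log units; within the scatter). Compound 4 is estimated at 90 nM, likely between 35 nM and 250 nM.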

Compound 4, half-maximal effective concentration: 730 nM
For compound 4 the middle estimate is 8.1-fold (0.91 log units) below the measured one; measured number outside the range, above it.
By their numbers in this assay, from the lowest: compounds 3, 2 and 1 (each within the scatter of the next); then compound 4.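

Among the compounds shown, this is the first change with a clear effect: methoxy in place of bromo on this aromatic carbon, meta to a bromo group, gives a 15-fold higher number from compound 3 to compound 4 (1.16 log units; beyond the scatter). The earlier compounds shown here could not be told apart, whereas this one replacement on an otherwise unchanged compound moves the number well beyond the scatter. No measurement at hand explains the size of this step. The compounds shown leave open how fluoro, an amine or a longer ether chain would fare on this carbon, and whether replacing the remaining bromo would have a similar effect.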